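A few compounds are considered here, and "the series" means these few. Any claim that something is new, unique, unknown or untested is made for them only; others in the source may bear on it.

Three compounds in the series have been run in a functional assay on MV4-11 cells (Homo sapiens) for antiproliferative activity, read by CCK-8 assay, with a stated time of 72 h; a lower number here means a stronger inhibitor, a higher number a weaker inhibitor. Compound 1 `Cn1cc(-c2cc(C(C)(C)O)ccc2OC2CC2)c2cc(C(=O)NCc3ccc(C(=O)Nc4ccccc4N)cc3)[nH]c2c1=O` gives 40 nM in this assay and stands lowest of the three: compound 3 `Cn1cc(-c2ccccc2Oc2ccccc2)c2cc(C(=O)NCCCCCCC(=O)Nc3ccccc3N)[nH]c2c1=O` gives 130 nM and compound 2 `Cn1cc(-c2ccccc2Oc2ccccc2)c2cc(C(=O)NCCCCC(=O)Nc3ccccc3N)[nH]c2c1=O` gives 240 nM, both steps to compound 1 lying beyond the scatter, so compound 1 is the strongest inhibitor measured so far. For the measured compounds named here, the one single-point step available, a 1.8-fold lower number from compound 2 to compound 3 (0.27 log units; within the scatter), concerns the chain between the amide-type nitrogen and the (2-aminophenyl)carbamoyl group and says nothing about the aryl ether end of the molecule.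

Compound 4 `COc1ccc(C(C)(C)O)cc1-c1cn(C)c(=O)c2[nH]c(C(=O)NCc3ccc(C(=O)Nc4ccccc4N)cc3)cc12` is not yet measured. It differs from compound 1 in one place: methyl in place of cyclopropyl on an oxygen on an aromatic ring, the oxygen in question sitting on an aromatic ring whose other neighbours are aromatic carbon. Going by the values given here, no measured pair carries this change, so there is no step to lean on; the expectation rests on the untouched remainder of the molecule, which compound 4 shares with compound 1. A step of a 1.5-fold higher number from compound 1 to compound 4 (0.18 log units; within the scatter) is expected, and for compound 4 the estimate in this assay is 60 nM, with a range from 25 nM to 150 nM.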

Compound 4, half-maximal inhibitory concentration: 420 nM
Estimate against measurement, compound 4: 7.0-fold (0.85 log units) below; the measured number lies above the stated range.
By their numbers in this assay, from the lowest: compound 1; then compounds 3, 2 and 4 (each within the scatter of the next, the first and the last beyond it).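

In this assay, the group on this oxygen proves to matter: the change from cyclopropyloxy to methoxy gives an 11-fold higher number from compound 1 to compound 4 (1.02 log units; beyond the scatter), with the rest of the molecule untouched. The counted difference is the loss of two heavy atoms and the three-membered ring, with no change in hydrogen-bond donors, hydrogen-bond acceptors or net charge, and the earlier step, confined to the chain, could not show that this end of the molecule is so sensitive. No measurement at hand accounts for the size of this step.

Open, as far as these compounds go, is whether ring or carbon count is what tracks with the number, a question that ethoxy, isopropoxy or cyclobutyloxy on the same oxygen would address. Also open, from the compounds shown here alone, is whether the step carries over to the saturated chains of compound 2 and compound 3.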